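A few compounds are considered here, and "the series" means these few. Any claim that something is new, unique, unknown or untested is made for them only; others in the source may bear on it.

Measured compounds in an ADME assay on Raji cells (Homo sapiens) for cytotoxicity, read by luminescence, with a stated time of 72 h; a lower number here means that less compound is needed, a higher number that more compound is needed for the effect:
Compound 1, `CCOC(=O)c1c(-c2cccc(-c3ccccc3)c2)[nH]c2cc(OC)ccc2c1=O`: compound 1 gives > 21500 nM, a limit of the assay.
Compound 2, `CCCOc1cccc(-c2[nH]c3cc(OC)ccc3c(=O)c2C(=O)OCC)c1`: compound 2 gives > 21500 nM, a limit of the assay.
Compound 3, `CCOC(=O)c1c(-c2cccc(C(C)=O)c2)[nH]c2cc(OC)ccc2c1=O`: compound 3 gives > 21500 nM, a limit of the assay.

Compound 1 stands only at a limit in this assay, and the other two values shown are limits as well, all sitting at the limit of > 21500 nM in this assay, at which 3 of the 3 values shown sit. The account follows the step from compound 1 to compound 4, `CCOC(=O)c1c(-c2cccc(NC(C)=O)c2)[nH]c2cc(OC)ccc2c1=O`, where the change is acetamido in place of phenyl on an aromatic carbon. The measured steps that bear on it are those at the same aromatic carbon: a step that the two limits leave unreadable from compound 1 to compound 2, a step that the two limits leave unreadable from compound 1 to compound 3 and a step that the two limits leave unreadable from compound 2 to compound 3. Each of these starts and ends at a limit; none gives a readable size or direction. Three different replacements at this position have all left the value at the limit, so for compound 4 no step beyond the scatter is expected in this assay, and the most likely outcome is once more a limit rather than a number. For compound 4 the estimate is 30000 nM, with a range from 15000 nM to 100000 nM. The step this estimate expects is a step that the limit leaves unreadable from compound 1 to compound 4.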

Compound 4, half-maximal effective concentration: > 21500 nM
Compound 4 gave a limit, no number; the forecaster's own chance of this, stated with the estimate: 85%; the middle value lies beyond the limit too.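

No step from compound 1, compound 2 or compound 3 to compound 4 can be read in this assay, as each starts and ends at a limit: the limit of > 21500 nM in this assay, at which 4 of the 4 values shown sit.

The compounds shown leave open whether any group at this aromatic carbon would give a number rather than a limit.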